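Swapping a Pyridine Attachment Point on a Chalcone Scaffold

The compounds below may be only part of what the source reports. "The series", "measured", "known", "first", "only" and "open" are said of these compounds alone.

Of the compounds shown here, three from this series have been tested in a functional assay on Huh-7 cells (Homo sapiens) for inhibition, read by sulforhodamine B assay, with a stated time of 72 h; on this read-out lower numbers stand for stronger inhibition and higher numbers for weaker inhibition. Compound 1, `O=C(/C=C/c1cn(-c2ccccc2)nc1-c1cccnc1)c1ccccc1`, gives 2300 nM in this assay. Compound 3, `O=C(/C=C/c1cn(-c2ccccc2)nc1-c1ccncc1)c1ccccc1`, differs from compound 1 only by pyridin-4-yl in place of pyridin-3-yl on an aromatic carbon, and in this assay compound 3 gives 1800 nM. The step of a 1.3-fold lower number from compound 1 to compound 3 (0.11 log units; within the scatter) is therefore small, and the two values cannot be ranked against each other.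

Compound 2, `COc1cc(OC)c(C(=O)/C=C/c2cn(-c3ccccc3)nc2-c2cccnc2)c(OC)c1`, shares part of its core with compound 1, but how the two cores differ is not broken down here. In this assay compound 2 gives 500 nM, the lowest of the three numbers, and its gap to compound 3 and to compound 1 lies beyond the usual scatter in both cases.

Compound 4, `COc1cc(OC)c(C(=O)/C=C/c2cn(-c3ccccc3)nc2-c2ccncc2)c(OC)c1`, has not yet been measured. It is made from compound 2 by pyridin-4-yl in place of pyridin-3-yl on an aromatic carbon. The place of the change is described in the same words as for the change from compound 1 to compound 3, so this is the same change, applied once more on the core of compound 2.

Within the data shown here, the only guide to its effect is the earlier step, so a step of about a 1.3-fold lower number from compound 2 to compound 4 (0.10 log units; within the scatter) is expected from compound 2 to compound 4. On that basis compound 4 is expected to give about 400 nM in this assay, with a likely range from 150 nM to 1000 nM.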

Compound 4, half-maximal inhibitory concentration: 2600 nM
Beside the measured number, compound 4's estimate is 6.5-fold (0.81 log units) below it; the whole stated range lies below it.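

The swap of pyridin-3-yl for pyridin-4-yl does not have one fixed size in this series, so its effect on one core cannot simply be carried over to another: the same change on two cores in this assay, a 1.3-fold lower number (0.11 log units; within the scatter) from compound 1 to compound 3 and a 5.2-fold higher number (0.72 log units; beyond the scatter) from compound 2 to compound 4, 6.6-fold (0.82 log units) apart, beyond the scatter of two such steps. On the core of compound 2 the swap gives a 5.2-fold higher number from compound 2 to compound 4 (0.72 log units; beyond the scatter) in this assay and so loses the advantage that compound 2 held, while on the core of compound 1 the same swap left two numbers too close to rank. Among these compounds, this shows that the outcome depends on the core the swap is made on, but with only two pairs it does not show which part of the core is responsible, why the two cores differ, or how the swap would behave on a third core.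

The compounds shown leave open how a pyridin-2-yl group or a plain phenyl group would read at this same place on each of the two cores. Also open, going by these compounds, is how the swap would behave on a core with fewer methoxy groups than compound 2, or on one carrying an amine in their stead.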